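Thiophenyl for Ethoxycarbonyl on a Shared Nucleoside Core

This account rests on a few compounds, and the source may have more. Where it says the series, first, only, none or still open, it means among the compounds named here.

Of the compounds shown here, three built on one shared core have been tested in a functional assay on HeLa cells (Homo sapiens) for cytotoxicity, read by MTT assay, with a stated time of 72 h; a higher number here means that more compound is needed for the effect, a lower number that less compound is needed. Compound 1 `CCOC(=O)c1cn(C[C@H]2O[C@@H](n3ccc(=O)[nH]c3=O)[C@H](SCC)[C@@H]2SCC)nn1` carries an ethoxycarbonyl group on its five-membered aromatic ring with three nitrogens. In this assay compound 1 gives >= 100000 nM, which is a limit of the assay and not a number. Compound 2 `CCS[C@@H]1[C@H](SCC)[C@@H](Cn2cc(-c3cccs3)nn2)O[C@H]1n1ccc(=O)[nH]c1=O` differs from compound 1 by thiophen-2-yl in place of ethoxycarbonyl on an aromatic carbon. In this assay compound 2 gives >= 100000 nM, again only a limit. Compound 3 `CCOC(=O)c1cn(C[C@H]2O[C@@H](n3cc(C)c(=O)[nH]c3=O)[C@H](SCC)[C@@H]2SCC)nn1` bears a methyl in place of hydrogen on an aromatic carbon of the six-membered ring. In this assay compound 3 gives >= 100000 nM, also a limit rather than a number. The step that the two limits leave unreadable from compound 1 to compound 2 and the step that the two limits leave unreadable from compound 1 to compound 3 cannot be sized because of the limit of >= 100000 nM in this assay, at which 3 of the 3 values shown sit.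

Compound 4 `CCS[C@@H]1[C@H](SCC)[C@@H](Cn2cc(-c3cccs3)nn2)O[C@H]1n1cc(C)c(=O)[nH]c1=O` has not yet been measured. It differs from compound 3 by thiophen-2-yl in place of ethoxycarbonyl on an aromatic carbon, the same change as from compound 1 to compound 2, made on a core that differs by methyl in place of hydrogen on an aromatic carbon. Since every measured value sits at the same limit, no direction for this change can be read. The step from compound 3 to compound 4 is therefore expected to be a number no higher from compound 3 to compound 4 (the limit leaves the size open), resting on compound 3 at >= 100000 nM and on compound 2 at >= 100000 nM. Compound 4 is estimated at 100000 nM, expected between 40000 nM and 300000 nM, most likely reported again only as a limit.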

Compound 4, half-maximal effective concentration: 54900 nM
Compound 4: middle estimate off by 1.8-fold (0.26 log units), on the high side, and the stated range covers the measured number.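

In this assay, thiophen-2-yl in place of ethoxycarbonyl on the core that carries the methyl gives an at least 1.8-fold lower number from compound 3 to compound 4 (0.26 log units; that floor lies within the scatter), while adding the methyl to the thiophen-2-yl compound gives an at least 1.8-fold lower number from compound 2 to compound 4 (0.26 log units; that floor lies within the scatter). Among these compounds, compound 4 is the only one of the four compounds with a measured number, and neither step has a known full size, because compound 3 and compound 2 each stand only at a limit: the limit of >= 100000 nM in this assay, at which 3 of the 4 values shown sit. This shows that the two changes together bring one compound onto a readable number, but the floors alone do not establish a difference beyond the scatter, and the unreadable steps from compound 1 neither confirm nor refute that the thiophen-2-yl change carries from one core to the other.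

The compounds shown leave open how far the number would move with an amine, a carboxylic acid or a longer chain on the same aromatic carbon of the five-membered ring. They also leave open whether the methyl and thiophen-2-yl must occur together for a readable number in this assay, since a single measured value cannot separate the part played by each change.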